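A few compounds are considered here, and "the series" means these few. Any claim that something is new, unique, unknown or untested is made for them only; others in the source may bear on it.

Measured so far:
- compound 1 `CCCCCCCCCCCCNc1nc(SCc2ccc(C(F)(F)F)cc2)nc2ccccc12`: 26000 nM
- compound 2 `Cc1ccccc1Nc1nc(SCc2ccc(C(F)(F)F)cc2)nc2ccccc12`: 36900 nM

In a functional assay on PC-3 cells (Homo sapiens) for cytotoxicity, read by MTT assay, with a stated time of 72 h (on this read-out lower numbers stand for stronger inhibition and higher numbers for weaker inhibition), compound 1 gives 26000 nM and compound 2 gives 36900 nM. Compound 2 has the higher of the two numbers, but the gap to compound 1 is within the usual scatter, so the two compounds cannot be told apart on these data. The two share the same core and differ only in the group on the ring nitrogen.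

Compound 3 `Cc1ccc(Nc2nc(SCc3ccc(C(F)(F)F)cc3)nc3ccccc23)cc1` has not yet been measured. It differs from compound 2 in one place: 4-methylphenyl in place of 2-methylphenyl on a nitrogen on an aromatic ring. Among the measured compounds shown here, no pair of measured compounds shows this kind of change, so there is no measured step to lean on.

With the same atoms merely joined differently, the expectation in this assay is a step of a 1.2-fold lower number from compound 2 to compound 3 (0.06 log units; within the scatter) from compound 2 to compound 3, none beyond the scatter in either direction. Compound 3 is estimated at 32000 nM, with a range from 12000 nM to 85000 nM.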

Compound 3, half-maximal inhibitory concentration: 21100 nM
For compound 3 the middle estimate is 1.5-fold (0.18 log units) above the measured one; the measured number falls inside the stated range.
By their numbers in this assay, from the lowest: compounds 3, 1 and 2 (each within the scatter of the next).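

Among the compounds shown here, replacing 2-methylphenyl with 4-methylphenyl on the nitrogen gives, in this assay, a 1.7-fold lower number from compound 2 to compound 3 (0.24 log units; within the scatter), the first measured step at this position. The two compounds have the same atoms, joined differently, so this step tests only where the methyl group sits on the phenyl ring, and on these data that placing does not separate compound 2 from compound 3. No measurement shown offers an explanation for the size of this step.

Both methylphenyl groups carry only carbon and hydrogen, so the compounds shown leave open whether a phenyl ring bearing a carboxylic acid, or a chain ending in an amine, on this nitrogen would give a step beyond the scatter. They also leave open whether changes elsewhere on the shared core would do so.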